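The compounds below may be only part of what the source reports. "The series", "measured", "known", "first", "only" and "open" are said of these compounds alone.

Compound 1 `CC1CCCc2c1nc(N)c(C#N)c2-c1cccn1C` gives 79400 nM in a functional assay on RPMI-8226 cells (Homo sapiens) for inhibition, read by sulforhodamine B assay, with a stated time of 48 h; on this read-out lower numbers stand for stronger inhibition of growth and higher numbers for weaker inhibition of growth.
Compound 2 `Cn1cccc1-c1cc(-c2cccs2)nc(N)c1C#N` gives only the limit > 100000 nM in this assay.
Compound 3 `Cn1cccc1-c1cc(-c2cccs2)[nH]c(=O)c1C#N` gives only the limit > 100000 nM in this assay.

Compound 2 thus stands at the edge of what this assay can report: its value is a limit, not a number, and the same is true of compound 3, so that the limit of > 100000 nM in this assay, at which 2 of the 3 values shown sit, marks where most of the known values sit. For the measured compounds named here, only compound 1 yields a numerical read-out, and it is not a single change away from any other compound here, so no measured step is available.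

Compound 4 `Cn1cccc1-c1cc(-c2ccccc2)nc(N)c1C#N` differs from compound 2 by phenyl in place of thiophen-2-yl on an aromatic carbon — phenyl in place of thiophen-2-yl on an aromatic carbon. Going by the values given here, with no measured step to lean on, and with compound 2 itself sitting at the limit of > 100000 nM in this assay, at which 2 of the 3 values shown sit, the change is expected to move the read-out by no more than the scatter, if at all; the estimated step from compound 2 to compound 4 in this assay is a step that the limit leaves unreadable from compound 2 to compound 4. Compound 4 is therefore expected to give about 120000 nM in this assay, within a range from 40000 nM to 400000 nM, and most likely to return again only a limit.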

Compound 4, concentration for 50% growth inhibition: 53700 nM
Compound 4: the middle estimate sits 2.2-fold (0.35 log units) above what was measured; the range from low to high includes it.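

At this position, the aromatic carbon next to the ring nitrogen, phenyl in place of thiophen-2-yl gives a numerical read-out, as compound 4 gives 53700 nM in this assay. The change amounts to an at least 1.8-fold lower number from compound 2 to compound 4 (0.27 log units; that floor lies within the scatter), so the shift is shown only as a floor and is not established as exceeding the scatter. The true size of the step cannot be read because compound 2 has only a limit as its value: the limit of > 100000 nM in this assay, at which 2 of the 4 values shown sit.

The compounds shown leave open whether a phenyl ring carrying a methoxy group or an amine at this carbon would move the read-out further. They also leave open whether phenyl in place of thiophen-2-yl would give a numerical read-out on compound 3, which carries a carbonyl where compound 2 has the amino group.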